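The source may hold more compounds than are shown below. What is called first, only, known or untested is meant among the compounds shown, and "the series" means these compounds.

Working notes on the series.

Among the measured compounds shown here, compound 1 `CC(C)(C)OC(=O)NCCCCCN1C(Nc2ccc(-c3ccccc3)cc2)=Nc2ccccc2C1CC(=O)NCc1ccccc1` carries the higher of the two numbers known so far. In an assay on HEK293 cells for inhibition of Voltage-dependent T-type calcium channel subunit alpha-1G (Homo sapiens), tested at 10 uM (on this read-out lower numbers stand for less inhibition and higher numbers for more inhibition at the one concentration tested (going by the name of the read-out)), compound 1 gives 88.5%. Its nearest neighbour is compound 2 `NCCCCCNC1=Nc2ccccc2C(CC(=O)NCc2ccccc2)N1c1ccc(-c2ccccc2)cc1`; in this assay compound 2 gives 83.8%, a value within the scatter of compound 1, so the two cannot be ordered on these data. For the measured compounds named here, no single-change step between measured compounds exists in the set, so nothing about the size of a single change has yet been observed.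

Compound 3 `COC(=O)CC1c2ccccc2N=C(Nc2ccc(-c3ccccc3)cc2)N1CCCCCNC(=O)OC(C)(C)C` is the next compound to go into this assay. Relative to compound 1 it differs in one place: methoxy in place of benzylamino on a carbonyl carbon. Going by the values given here, the two measured compounds both sit high in this assay, and they offer no precedent for trading a benzylamino for a methoxy on a carbonyl carbon. The expectation is a modest step downward, somewhat beyond the scatter, rather than none at all: the step from compound 1 to compound 3 is estimated at a number 14.5 percentage points lower from compound 1 to compound 3 (beyond the scatter). For compound 3 in this assay the estimate is 74%, with a range from 55% to 90%.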

Compound 3, a percentage reported as inhibition, at one concentration (the size of the read-out at that concentration, not a potency): 88.5%
Beside the measured number, compound 3's estimate is 14.5 percentage points below it; the range from low to high includes it.
By their numbers in this assay, from the lowest: compounds 2, 1 and 3 (each within the scatter of the next).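

In this assay, among the compounds shown here, the first single-change step reads no change at the digits printed from compound 1 to compound 3 (within the scatter), so the size of one change at this position has now been observed. On a carbonyl carbon whose other neighbours are saturated chain carbon, in the setting of compound 1, the whole benzylamino group, with its six-membered aromatic ring of carbon only and its hydrogen-bond donor, gives way to methoxy without a step beyond the scatter; the inhibition seen at this one concentration therefore does not depend on the benzylamino group in this setting. The read-out is a size at a single concentration and not a potency, and no measured information on the result offers an explanation for it.

On these data alone, whether a carboxylic acid, a primary amide or a longer alkoxy group such as ethoxy on the same carbonyl carbon would read the same remains open. So does whether methoxy in place of benzylamino would give the same step in the setting of compound 2, and whether compound 1 and compound 3 would stay together at lower concentrations.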